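Swapping Methoxy for Chloro: Expecting Compound 3

The source may hold more compounds than are shown below. What is called first, only, known or untested is meant among the compounds shown, and "the series" means these compounds.

Measured compounds:
compound 1 `Cc1ccc(NC2=CC(=O)c3nc4n(c3C2=O)[C@H]2OC[C@@H](O)[C@H]2OC4)cc1`: 3480 nM
compound 2 `COc1cccc(NC2=CC(=O)c3c(nc4n3[C@H]3OC[C@@H](O)[C@H]3OC4)C2=O)c1`: 3340 nM

In a functional assay on ECa-109 cells for inhibition, with ECa-109 cell line (Homo sapiens) as the target, read by sulforhodamine B assay (a higher number here means a weaker inhibitor, a lower number a stronger inhibitor), compound 1 gives 3480 nM and compound 2 gives 3340 nM. Compound 2 has the lower of the two numbers, but its gap to compound 1 lies within the scatter, so the two compounds cannot be told apart on these data. Compound 3 `O=C1C(Nc2cccc(Cl)c2)=CC(=O)c2c1nc1n2[C@H]2OC[C@@H](O)[C@H]2OC1` has not yet been measured in this assay. It differs from compound 2 in one place: chloro in place of methoxy on an aromatic carbon. Going by the values given here, no pair of measured compounds shows what such a change does, so there is no measured step to lean on. Among the compounds with values here, the only guide is that the two measured compounds, carrying different groups on the six-membered aromatic ring of carbon only, sit within the scatter of each other. The expected step is a 1.1-fold lower number from compound 2 to compound 3 (0.05 log units; within the scatter), none beyond the scatter. Compound 3 is therefore estimated at 3000 nM, with a range from 1200 nM to 8000 nM.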

Compound 3, half-maximal inhibitory concentration: 3080 nM
Estimate against measurement, compound 3: 1.0-fold (0.01 log units) below, and the stated range covers the measured number.
By their numbers in this assay, from the lowest: compounds 3, 2 and 1 (each within the scatter of the next).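

Compound 3 and compound 2 form the only pair shown that differs in a single place, which makes this the one direct reading of a change on this ring. In this assay, chloro in place of methoxy on this aromatic carbon, meta to a large group, gives a 1.1-fold lower number from compound 2 to compound 3 (0.04 log units; within the scatter) and so leaves the two compounds indistinguishable, even though a group of two heavy atoms with one hydrogen-bond acceptor gives way to a single atom with none. Nothing measured here explains why these two groups read alike.

Going by these compounds alone, the pair covers only two small neutral groups at one position, so it cannot show whether this position tolerates every change. An amine, a carboxylic acid or a longer chain such as butoxy on the same carbon could move the number well beyond the scatter or leave it where it is.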